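Freeing the ring nitrogen of compound 3

The source may report more compounds than this note shows. Statements on the series, on what has been measured and on what is new or still open speak of the compounds shown alone.

Compound 1 `COc1cccc(/C=C2\CCC=CC2=O)c1OC` gives 4710 nM
Compound 2 `O=C1C=CCC/C1=C\c1cccnc1` gives 2030 nM
Compound 3 `COc1cc(/C=C2\CN(C(=O)OCc3ccccc3)C=CC2=O)cc(OC)c1OC` gives > 25000 nM as a limit of the assay

All three were tested in a functional assay on MCF7 cells (Homo sapiens) for antiproliferative activity, read by sulforhodamine B assay, with a stated time of 72 h (on this read-out higher numbers stand for weaker inhibition and lower numbers for stronger inhibition), and two of them returned numbers. Among the compounds with values here, compound 3 stands apart with a limit and no number, as the one compound at the limit of > 25000 nM in this assay, at which 1 of the 3 values shown sits, in this small set.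

Compound 4 `COc1cc(/C=C2\CNC=CC2=O)cc(OC)c1OC` has not yet been measured. It carries hydrogen in place of benzyloxycarbonyl on an amine nitrogen in a ring and otherwise matches compound 3.

Within the data shown here, no measured pair shows this change, so the expectation rests on thin ground. Compound 1 at 4710 nM and compound 2 at 2030 nM carry no benzyloxycarbonyl and still give numbers, though on a different core. In this assay a shift toward stronger inhibition is therefore expected, of moderate size, and the estimated step of an at least 2.5-fold lower number from compound 3 to compound 4 (0.39 log units; beyond the scatter) is uncertain because its starting point is only a limit. For compound 4 the expected value is 10000 nM with a range from 2500 nM to 25000 nM as estimated.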

Compound 4, half-maximal inhibitory concentration: > 25000 nM
Compound 4: only a limit was reported; the forecaster's own chance of this, stated with the estimate: 30%; middle value at least 2.5-fold (0.39 log units) away from the limit.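

In this assay compound 4 gives > 25000 nM, which is a limit of the assay and not a number. Compound 3 also stands at a limit, so no step can be read between compound 3 and compound 4: the limit of > 25000 nM in this assay, at which 2 of the 4 values shown sit. The compounds shown leave open whether hydrogen in place of benzyloxycarbonyl changes the inhibition at all.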